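Replacing the carboxy group in compound 2

The source may hold more compounds than are shown below. What is called first, only, known or untested is meant among the compounds shown, and "the series" means these compounds.

compound 1 `O=C(N[C@@H]1CNCC[C@H]1c1ccc(Cl)cc1)c1ccc(-c2ncnc3c2CCC3O)s1` — > 1000 nM
compound 2 `Cn1ncc(Cl)c1-c1cc(C(=O)N[C@@H]2CN[C@H](CC(=O)O)C[C@H]2c2ccc(Cl)c(Cl)c2)oc1Cl` — 1.94 nM
compound 3 `CNC(=O)C[C@@H]1C[C@@H](c2ccc(Cl)c(Cl)c2)[C@H](NC(=O)c2cc(-c3c(Cl)cnn3C)c(Cl)o2)CN1` — 2.64 nM

In an assay for inhibition of RAC-alpha serine/threonine-protein kinase (Homo sapiens), read by HTRF, with a stated time of 1 h (a higher number here means a weaker inhibitor, a lower number a stronger inhibitor), compound 2 gives 1.94 nM, the lowest of the two numbers shown. Compound 3 gives 2.64 nM, within the scatter of compound 2. The value of compound 1, > 1000 nM, is a limit of the assay (the limit of > 1000 nM in this assay, at which 1 of the 3 values shown sits).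

Compound 4 `Cn1ncc(Cl)c1-c1cc(C(=O)N[C@@H]2CN[C@H](CC(O)CO)C[C@H]2c2ccc(Cl)c(Cl)c2)oc1Cl` differs from compound 2 in one place: 1,2-dihydroxyethyl in place of carboxy on a saturated chain carbon bound to a saturated ring carbon. Among the compounds with values here, the only measured step at this position is a 1.4-fold higher number from compound 2 to compound 3 (0.13 log units; within the scatter), where methylamino replaced the carboxy without leaving the scatter. On that evidence the step to compound 4 is expected to remain small, with no clear direction. Compound 4 is estimated at 3 nM, with a range from 1 nM to 10 nM. This estimate means an expected step of a 1.5-fold higher number from compound 2 to compound 4 (0.19 log units; within the scatter).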

Compound 4, half-maximal inhibitory concentration: 3.79 nM
Compound 4: middle estimate off by 1.3-fold (0.10 log units), on the low side, within the range that was stated.
By their numbers in this assay, from the lowest: compounds 2, 3 and 4 (each within the scatter of the next). At a limit, above all of these: compound 1.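

In this assay, 1,2-dihydroxyethyl in place of carboxy stays within the scatter (a 2.0-fold higher number from compound 2 to compound 4 (0.29 log units; within the scatter)), so this position tolerates a second replacement, and this one has no carbonyl at all. Set against methylcarbamoyl, the same group also stays within the scatter (a 1.4-fold higher number from compound 3 to compound 4 (0.16 log units; within the scatter)). The compounds shown give no measured reason for these small steps. What they leave open is whether an amine, a longer chain or a plain methyl group in place of the carboxy would keep the number as low.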